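Replacing a Sulfonyl Group by Methoxy: Expected Cytotoxicity

The source may hold more compounds than are shown below. What is called first, only, known or untested is meant among the compounds shown, and "the series" means these compounds.

Of the compounds shown here, two sharing one core have been tested in an ADME assay on PC-3 cells (Homo sapiens) for cytotoxicity, read by WST assay, tested at 100 uM; a lower number here means less inhibition, a higher number more inhibition at the concentration tested (going by the name of the read-out). Compound 1 `O=C(Nc1cccc(OCCc2ccccn2)c1)C1CCCN(C(=O)c2cc(C(F)(F)F)cc(C(F)(F)F)c2)C1` gives 5% there, and compound 2 `O=C(Nc1cccc(S(=O)(=O)N2CCCC2)c1)C1CCCN(C(=O)c2cc(C(F)(F)F)cc(C(F)(F)F)c2)C1` gives 0%. The step of a number 5 percentage points lower from compound 1 to compound 2 (within the scatter) shows that exchanging one side group for another hardly moved the read-out. On the numbers at hand compound 2 stands at the bottom, with compound 1 its nearest neighbour and the gap between them within the scatter.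

Compound 3 `COc1cccc(NC(=O)C2CCCN(C(=O)c3cc(C(F)(F)F)cc(C(F)(F)F)c3)C2)c1` has not yet been measured. It differs from compound 2 in one place: methoxy in place of (pyrrolidin-1-yl)sulfonyl on an aromatic carbon. Going by the values given here, the only measured step, from compound 1 to compound 2, lay within the scatter, so nothing here suggests that changing this part of the molecule shifts this assay beyond the scatter. For compound 3 the expected step is therefore a number 3 percentage points higher from compound 2 to compound 3 (within the scatter), no change beyond the scatter. Compound 3 is estimated to give 3%, within a range from -8% to 15%.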

Compound 3, a percentage reported as inhibition, at one concentration (the size of the read-out at that concentration, not a potency): 0%
Estimate against measurement, compound 3: 3 percentage points above, within the range that was stated.
By their numbers in this assay, from the lowest: compounds 2, 3 and 1 (each within the scatter of the next).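

In this assay, methoxy, with 2 heavy atoms and no ring, takes the place of (pyrrolidin-1-yl)sulfonyl, with 8 heavy atoms and a five-membered non-aromatic ring, and the result is no change at the digits printed from compound 2 to compound 3 (within the scatter). Cutting the 2-(pyridin-2-yl)ethoxy group back to methoxy gives a number 5 percentage points lower from compound 1 to compound 3 (within the scatter), so these three quite different groups on this aromatic carbon, meta to a large group, all lie within the scatter of one another. No measurement at hand says why the read-out stays so flat.

From the compounds shown here alone, whether an amine or a carboxylic acid on this same carbon would move the number beyond the scatter remains open. Also open, going by these compounds, is whether a change elsewhere in the shared core, such as chlorine in place of trifluoromethyl, would do so.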